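A few compounds are considered here, and "the series" means these few. Any claim that something is new, unique, unknown or untested is made for them only; others in the source may bear on it.

Compound 1 `CCN(CC)S(=O)(=O)c1ccc(S(=O)(=O)N2CCC[C@@H](C(=O)N3CCC(O)CC3)C2)cc1` was tested in a functional assay on MIA PaCa-2 cells (Homo sapiens) for inhibition, read by MTT assay, with a stated time of 7 days (a higher number here means a weaker inhibitor, a lower number a stronger inhibitor), where compound 1 gives 870 nM. Within the data shown here, that is the highest of the two numbers measured so far. Among the measured compounds shown here, compound 2 `O=C([C@@H]1CCCN(S(=O)(=O)c2ccc(S(=O)(=O)C3CC3)cc2)C1)N1CCC(F)(F)CC1` gives 26 nM in this assay, a lower number by a margin beyond the usual scatter; the two compounds differ in more than one place, so no single step connects them. Compound 3 `CCN(CC)S(=O)(=O)c1ccc(S(=O)(=O)N2CCC[C@@H](C(=O)N[C@H]3CCOC3)C2)cc1` has not yet been measured. It differs from compound 1 in one place: (oxolan-3-yl)amino in place of 4-hydroxypiperidin-1-yl on a carbonyl carbon. The amide on the shared core thus changes from one without an amide hydrogen to one that carries an amide hydrogen. For the measured compounds named here, no measured pair shows what such a change does here. A modest loss of potency, or no change beyond the scatter, is expected, and the step of a 1.7-fold higher number from compound 1 to compound 3 (0.24 log units; within the scatter) is an estimate in that sense. Compound 3 is expected to give about 1500 nM in this assay, with a range from 400 nM to 6000 nM.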

Compound 3, half-maximal inhibitory concentration: 1670 nM
The estimate for compound 3 lay 1.1-fold (0.05 log units) below the measured number, within the range that was stated.
By their numbers in this assay, from the lowest: compound 2; then compounds 1 and 3 (each within the scatter of the next).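

In this assay, placing (oxolan-3-yl)amino on the carbonyl carbon in place of 4-hydroxypiperidin-1-yl gives a 1.9-fold higher number from compound 1 to compound 3 (0.28 log units; within the scatter), the first single-place step available at this position. An amide without an amide hydrogen and one that carries it therefore cannot be told apart here, and neither can the six-membered and five-membered rings these two groups bring. No measurement bears on why the two compounds read alike.

This single step leaves open how a group without a ring, such as ethylamino, or one carrying a carboxylic acid would read on this carbonyl carbon. It also leaves open whether the opposite stereoisomer of (oxolan-3-yl)amino would give a number within the scatter of compound 3.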